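A few compounds are considered here, and "the series" means these few. Any claim that something is new, unique, unknown or untested is made for them only; others in the source may bear on it.

Compound 2, `CC1=CC[C@@H]([C@@](C)(O)CCCC(C)(C)NC(=S)N/N=C\c2ccc(N(C)C)cc2)CC1`, was tested in a functional assay on OVCAR-3 cells (Homo sapiens) for cytotoxicity, read by sulforhodamine B assay; on this read-out higher numbers stand for weaker inhibition of growth and lower numbers for stronger inhibition of growth. In this assay compound 2 gives only a limit, > 100000 nM, and not a number (the limit of > 100000 nM in this assay, at which 1 of the 2 values shown sits). Compound 1, `CC1=CC[C@@H]([C@@](C)(O)CCCC(C)(C)NC(=S)N/N=C\c2ccccc2)CC1`, differs from compound 2 only by the dimethylamino group, and in this assay compound 1 gives 12900 nM. For the measured compounds named here, the single measured step between these two is an at least 7.7-fold higher number from compound 1 to compound 2 (0.88 log units; beyond the scatter). Compound 3, `CC1=CC[C@@H]([C@@](C)(O)CCCC(C)(C)NC(=S)N/N=C\c2cccc(Cl)c2)CC1`, has not yet been measured; it carries 3-chlorophenyl in place of 4-(dimethylamino)phenyl on a carbon with a double bond to nitrogen. Going by the values given here, since the dimethylamino group that accompanies the weaker result of compound 2 is absent in compound 3, the step of an at least 7.7-fold higher number from compound 1 to compound 2 (0.88 log units; beyond the scatter) bears on this change and points to the number coming back down, while no measured step covers a chlorine on the ring in place of hydrogen, so the size is open. Compound 3 is therefore expected to show a step of an at least 8.3-fold lower number from compound 2 to compound 3 (0.92 log units; beyond the scatter) in this assay. The estimate for compound 3 is 12000 nM, with a range from 3000 nM to 60000 nM.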

Compound 3, concentration for total growth inhibition: 26500 nM
Compound 3: the middle estimate sits 2.2-fold (0.34 log units) below what was measured; the measured number falls inside the stated range.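

In this assay, 3-chlorophenyl in place of 4-(dimethylamino)phenyl on a carbon with a double bond to nitrogen gives an at least 3.7-fold lower number from compound 2 to compound 3 (0.57 log units; beyond the scatter), so this position can return to a measurable number once the dimethylamino group is gone. The return is not complete, as chloro in place of hydrogen on an aromatic carbon gives a 2.1-fold higher number from compound 1 to compound 3 (0.31 log units; beyond the scatter), and among these three compounds the unsubstituted phenyl of compound 1 therefore shows the strongest growth inhibition. Compound 2 stands at a limit of the assay and not at a number, so the first step gives only a minimum size: the limit of > 100000 nM in this assay, at which 1 of the 3 values shown sits.

Going by these compounds, whether a methoxy group, a fluorine or a carboxylic acid on this ring would stay as close to compound 1 remains open. Also open, on these data alone, is whether the result for compound 3 belongs to chlorine itself or to its place on the ring.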